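Heteroaryl Swaps at One Ring Carbon of a Shared Core

The source may report more compounds than this note shows. Statements on the series, on what has been measured and on what is new or still open speak of the compounds shown alone.

Three compounds share one core and differ only in the aryl group on a double-bonded ring carbon. Compound 1 `C[C@@H](O[C@H]1CN2C(=O)C=C(c3ccccc3)CC2[C@@H]1c1ccc(F)cc1)c1cc(C(F)(F)F)cc(C(F)(F)F)c1` carries a phenyl there, and in an assay on CHO cells for displacement of a labelled ligand from Substance-P receptor (Homo sapiens) (a lower number here means a stronger inhibitor, a higher number a weaker inhibitor), compound 1 gives 0.93 nM. Compound 2 `Cc1cc(C2=CC(=O)N3C[C@H](O[C@H](C)c4cc(C(F)(F)F)cc(C(F)(F)F)c4)[C@@H](c4ccc(F)cc4)C3C2)ccn1`, with a 2-methylpyridin-4-yl, gives 0.51 nM in this assay, and compound 3 `C[C@@H](O[C@H]1CN2C(=O)C=C(c3cnn(C)c3)CC2[C@@H]1c1ccc(F)cc1)c1cc(C(F)(F)F)cc(C(F)(F)F)c1`, with a 1-methyl-1H-pyrazol-4-yl, gives 0.13 nM. Compound 3 thus stands at the lowest number of the three: a 3.9-fold lower number from compound 2 to compound 3 (0.59 log units; beyond the scatter) and a 7.2-fold lower number from compound 1 to compound 3 (0.85 log units; beyond the scatter), both beyond the scatter, while a 1.8-fold lower number from compound 1 to compound 2 (0.26 log units; within the scatter).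

Compound 4 `CCc1noc(C2=CC(=O)N3C[C@H](O[C@H](C)c4cc(C(F)(F)F)cc(C(F)(F)F)c4)[C@@H](c4ccc(F)cc4)C3C2)n1` continues the replacements at the same carbon: 3-ethyl-1,2,4-oxadiazol-5-yl in place of 1-methyl-1H-pyrazol-4-yl on a double-bonded ring carbon. Among the measured compounds shown here, the steps that bear on it are the two earlier heteroaryl swaps into this position, a 7.2-fold lower number from compound 1 to compound 3 (0.85 log units; beyond the scatter) and a 3.9-fold lower number from compound 2 to compound 3 (0.59 log units; beyond the scatter), modest in size and both toward lower numbers. For the measured compounds named here, no measured pair shows an oxadiazole or an ethyl chain at this carbon, so the direction of the new step is open. Because compound 3 already gives 0.13 nM, the lowest of the set, a modest move back toward the numbers of compound 1 and compound 2 seems somewhat more likely than a further gain. Compound 4 is therefore expected to give 0.3 nM in this assay, within 0.08 nM to 1.2 nM. This estimate means an expected step of a 2.3-fold higher number from compound 3 to compound 4 (0.36 log units; beyond the scatter), near the edge of the scatter.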

Compound 4, half-maximal inhibitory concentration: 0.4 nM
Estimate against measurement, compound 4: 1.3-fold (0.12 log units) below, and the stated range covers the measured number.
By their numbers in this assay, from the lowest: compound 3; then compounds 4, 2 and 1 (each within the scatter of the next, the first and the last beyond it).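

The result shows that a five-membered aromatic ring at this carbon does not by itself carry the low number of compound 3: in this assay there is a 3.1-fold higher number from compound 3 to compound 4 (0.49 log units; beyond the scatter) when 3-ethyl-1,2,4-oxadiazol-5-yl takes the place of 1-methyl-1H-pyrazol-4-yl. The position still tolerates this larger group with its third ring hetero atom, since there is a 2.3-fold lower number from compound 1 to compound 4 (0.37 log units; beyond the scatter) against the phenyl, while a 1.3-fold lower number from compound 2 to compound 4 (0.11 log units; within the scatter) leaves the oxadiazole and the 2-methylpyridin-4-yl indistinguishable in this measurement. Among these four compounds, then, the 1-methyl-1H-pyrazol-4-yl remains alone at the low end, and nothing given here accounts for the differences between these groups.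

Compound 4 alters the ring and its chain together, so these compounds cannot say whether the oxadiazole or the ethyl chain accounts for the step away from compound 3. A 1-ethylpyrazol-4-yl group, or a 1,2,4-oxadiazol-5-yl ring carrying a methyl or a longer propyl chain, would separate the two, and an amine on the ring remains an open variation at this carbon.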